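This account rests on a few compounds, and the source may have more. Where it says the series, first, only, none or still open, it means among the compounds named here.

In an ADME assay on MRC5 cells (Homo sapiens) for cytotoxicity, read by fluorescence and resazurin assay, with a stated time of 3 days (on this read-out higher numbers stand for weaker inhibition and lower numbers for stronger inhibition), compound 1 `Cc1cn(C2CCN(Cc3cccc(Oc4cccc(F)c4)c3)CC2)c(=O)[nH]c1=O` gives > 64000 nM, which is a limit and not a number. Compound 2 `Cc1cn(C2CCN(Cc3cccc(Oc4ccc(F)c(F)c4)c3)CC2)c(=O)[nH]c1=O` gives > 64000 nM, also a limit. Compound 3 `Cc1cn(C2CCN(Cc3cccc(Oc4cc(F)cc(F)c4)c3)CC2)c(=O)[nH]c1=O` gives > 64000 nM, likewise a limit. The three therefore stand together at the limit of > 64000 nM in this assay, at which 3 of the 3 values shown sit. The measured changes offer only a step that the two limits leave unreadable from compound 1 to compound 2, a step that the two limits leave unreadable from compound 1 to compound 3 and a step that the two limits leave unreadable from compound 2 to compound 3, so none supplies a size. Compound 4 `Cc1cn(C2CCN(Cc3cccc(Oc4cccc(Cl)c4)c3)CC2)c(=O)[nH]c1=O` follows with 3-chlorophenyl in place of 3,5-difluorophenyl on an oxygen on an aromatic ring, placing 3-chlorophenyl where 3,5-difluorophenyl stood. Among the measured compounds shown here, no measured step involves the 3-chlorophenyl group, so the expectation rests on the limit alone, and no step beyond the scatter is expected in this assay. The estimated step is an at least 1.0-fold lower number from compound 3 to compound 4 (0.02 log units; that floor lies within the scatter). Compound 4 is expected at 60000 nM, with an estimated range of 30000 nM to 64000 nM.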

Compound 4, half-maximal inhibitory concentration: 21000 nM
For compound 4 the middle estimate is 2.9-fold (0.46 log units) above the measured one, and the stated range ends above it.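

In this assay, among the compounds shown here, swapping to the 3-chlorophenyl group on an oxygen on an aromatic ring gives the only value of the four that is not a limit: the limit of > 64000 nM in this assay, at which 3 of the 4 values shown sit. The change reads as an at least 3.0-fold lower number from compound 3 to compound 4 (0.48 log units; beyond the scatter), as an at least 3.0-fold lower number from compound 2 to compound 4 (0.48 log units; beyond the scatter) and as an at least 3.0-fold lower number from compound 1 to compound 4 (0.48 log units; beyond the scatter), so this place can move the read-out. The steps among compound 1, compound 2 and compound 3 cannot be read.

On these data alone, the full size of these steps stays open, as each has only a floor. Also open, as far as these compounds go, is how a 3,5-dichlorophenyl, a nitrile or an amine would read in this place.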